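A Methoxyphenyl Swap at a Position with Low Numbers

The source may report more compounds than this note shows. Statements on the series, on what has been measured and on what is new or still open speak of the compounds shown alone.

Of the compounds shown here, two built on a shared core have been measured in a functional assay on NCI-H23 cells (Homo sapiens) for inhibition, read by sulforhodamine B assay, with a stated time of 48 h, tested at 10 uM; a lower number here means less inhibition, a higher number more inhibition at the concentration tested (going by the name of the read-out). Compound 1 `Brc1cn2ccnc2c(-c2ccc3ncn(C4CCCCC4)c3c2)n1` gives 10.2% in this assay, and compound 2 `Brc1ccc(-c2cn3ccnc3c(-c3ccc4ncn(C5CCCCC5)c4c3)n2)cc1` gives 8.38%. Going by the values given here, the one step between them, a number 1.8 percentage points lower from compound 1 to compound 2 (within the scatter), is small enough to lie within the scatter, so the two numbers cannot be ordered. Compound 2 holds the lower of the two numbers, but only by a margin that repeated measurement could erase.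

Compound 3 `COc1ccccc1-c1cn2ccnc2c(-c2ccc3ncn(C4CCCCC4)c3c2)n1` has not yet been measured. It differs from compound 2 in a single place: 2-methoxyphenyl in place of 4-bromophenyl on an aromatic carbon. Among the compounds with values here, no measured step exchanges one aryl group for another at this carbon; the only step at the same carbon, a number 1.8 percentage points lower from compound 1 to compound 2 (within the scatter), stayed within the scatter, and both measured numbers in this assay are low. Compound 3 is therefore expected to remain close to compound 2, with an expected step of a number 0.6 percentage points higher from compound 2 to compound 3 (within the scatter). The estimate for compound 3 in this assay is 9%, with a range from 0% to 22%.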

Compound 3, a percentage reported as inhibition, at one concentration (the size of the read-out at that concentration, not a potency): 2.79%
Compound 3: the middle estimate sits 6.2 percentage points above what was measured; low and high end bracket the measured number.
By their numbers in this assay, from the lowest: compounds 3, 2 and 1 (each within the scatter of the next).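

Within this assay, the first exchange of one aryl group for another on this carbon gives a number 5.6 percentage points lower from compound 2 to compound 3 (within the scatter) and thus stays inside the usual variation of the measurement. Replacing the bromo directly with 2-methoxyphenyl gives a number 7.4 percentage points lower from compound 1 to compound 3 (within the scatter) and is also not a step that can be read as a real difference, so the position has now carried a bromo, a 4-bromophenyl and a 2-methoxyphenyl with no separation among the three numbers. The entering group brings one hydrogen-bond acceptor where the 4-bromophenyl has none and a different place of substitution on the aryl ring, yet no evidence here bears on what either feature does to the result.

The three compounds leave open whether any group on this carbon can move the number beyond the scatter, for example an amine, a carboxylic acid or a longer chain. They also cannot separate the place of the substituent from its identity, which 4-methoxyphenyl or 2-bromophenyl on the same carbon would address.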